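Chain length at the basic tail and cytotoxic potency

The compounds below may be only part of what the source reports. "The series", "measured", "known", "first", "only" and "open" are said of these compounds alone.

Compound 1 `Cc1ccc2oc(-c3ccc(NC(=O)CN4CCN(CCN(C)C)CC4)cc3)nc2c1` gives 3660 nM in a functional assay on A549 cells (Homo sapiens) for cytotoxicity, read by MTT assay, with a stated time of 24 h; on this read-out higher numbers stand for weaker inhibition and lower numbers for stronger inhibition. Compound 3 `Cc1ccc2oc(-c3ccc(NC(=O)CN4CCN(CCCN(C)C)CC4)cc3)nc2c1` differs from it in one place, ((dimethylamino)methyl in place of dimethylamino on a saturated chain carbon, two bonds along the chain from an amine nitrogen in a ring), and gives 10600 nM, so that a 2.9-fold higher number from compound 1 to compound 3 (0.46 log units; beyond the scatter). Compound 2 `Cc1cc(-c2nc3cc(Cl)ccc3o2)ccc1NC(=O)CN1CCN(CCN(C)C)CC1` gives 24400 nM; how its core differs from that of compound 1 is not broken down here. Compound 4 `Cc1cc(-c2nc3cc(Cl)ccc3o2)ccc1NC(=O)CN1CCN(CCCN(C)C)CC1` has not yet been tested. It differs from compound 2 by (dimethylamino)methyl in place of dimethylamino on a saturated chain carbon, two bonds along the chain from an amine nitrogen in a ring, the same change in the same place as was seen from compound 1 to compound 3. Among the compounds with values here, the step is expected to be similar, a 2.5-fold higher number from compound 2 to compound 4 (0.39 log units; beyond the scatter), because the only example of this change, a 2.9-fold higher number from compound 1 to compound 3 (0.46 log units; beyond the scatter), went toward a higher number. Compound 4 is therefore estimated at 60000 nM, with a plausible range from 22000 nM to 160000 nM.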

Compound 4, half-maximal inhibitory concentration: 10500 nM
For compound 4 the middle estimate is 5.7-fold (0.76 log units) above the measured one; measured number below the stated range.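

On the core of compound 2, putting (dimethylamino)methyl in place of dimethylamino gives a 2.3-fold lower number from compound 2 to compound 4 (0.37 log units; beyond the scatter), so in this assay the step runs the opposite way from the one on the core of compound 1: the same change on two cores in this assay, a 2.9-fold higher number (0.46 log units; beyond the scatter) from compound 1 to compound 3 and a 2.3-fold lower number (0.37 log units; beyond the scatter) from compound 2 to compound 4, 6.7-fold (0.83 log units) apart, beyond the scatter of two such steps

This change therefore cannot be carried from one of these cores to the other with its direction kept. These two pairs do not show which of the differences between the cores goes with the reversal, nor how a third core would respond.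

The compounds shown leave open how a longer chain would behave on either core. They also leave open whether a cyclic amine such as morpholine, in place of the dimethylamino end, would follow either trend.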